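The source may report more compounds than this note shows. Statements on the series, on what has been measured and on what is new or still open speak of the compounds shown alone.

In a functional assay on LNCaP cells (Homo sapiens) for cytotoxicity (on this read-out higher numbers stand for weaker inhibition and lower numbers for stronger inhibition), compound 2 `CNC(=O)Nc1ccc(-c2nc(N3CC4CCC(C3)O4)c3cnn(C)c3n2)cc1` gives 170 nM, the highest number of the three measured compounds and so the weakest inhibition among them. Compound 3 `CNC(=O)Nc1ccc(-c2nc(N3CC4CCC(C3)O4)c3cnn([C@H]4CC[C@@H](O)CC4)c3n2)cc1` gives 20 nM, and compound 1 `CNC(=O)Nc1ccc(-c2nc(N3CC4CCC(C3)O4)c3cnn(C(C)C)c3n2)cc1` gives 5 nM. Compound 4 `CNC(=O)Nc1ccc(-c2nc(N3CC4CCC(C3)O4)c3cnn([C@H]4CC[C@H](O)CC4)c3n2)cc1` has not yet been measured. It differs from compound 2 at one place, on an aromatic nitrogen: 4-hydroxycyclohexyl in place of methyl on an aromatic nitrogen.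

The closest guide is an 8.5-fold lower number from compound 2 to compound 3 (0.93 log units; beyond the scatter), a modest step for 4-hydroxycyclohexyl in place of methyl. Going by the values given here, compound 3 carries the same named group as compound 4, but the two differ in the arrangement at its stereocentres, and no measurement yet shows how much that counts. Two further steps show what changes at this nitrogen can do: a 34-fold higher number from compound 1 to compound 2 (1.53 log units; beyond the scatter), which is large, and a 4.0-fold higher number from compound 1 to compound 3 (0.60 log units; beyond the scatter), which is modest.

Among the compounds with values here, a modest step towards a lower number is therefore expected in this assay, somewhat smaller than the one seen for compound 3. The expected step is a 5.7-fold lower number from compound 2 to compound 4 (0.75 log units; beyond the scatter). For compound 4 the estimated value is 30 nM, with an expected range of 8 nM to 110 nM.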

Compound 4, half-maximal inhibitory concentration: 20 nM
For compound 4 the middle estimate is 1.5-fold (0.18 log units) above the measured one; low and high end bracket the measured number.
By their numbers in this assay, from the lowest: compound 1; then compounds 3 and 4 (each within the scatter of the next); then compound 2.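

Going by these compounds alone, measured in this assay the two drawn arrangements of the 4-hydroxycyclohexyl group cannot be told apart (no change at the digits printed from compound 3 to compound 4 (within the scatter)), which the earlier compounds could not show. The advantage of this group over methyl therefore holds for both arrangements (an 8.5-fold lower number from compound 2 to compound 4 (0.93 log units; beyond the scatter)), and neither arrangement matches isopropyl (a 4.0-fold higher number from compound 1 to compound 4 (0.60 log units; beyond the scatter)). One caution applies when reading the pair of compound 3 and compound 4 as a clean test of arrangement: the fact that one of compounds 3 and 4 is drawn with a defined configuration and the other without, at the place where they differ.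

As far as these compounds go, it remains open whether a plain cyclohexyl group, without the hydroxyl, would come closer to isopropyl than the 4-hydroxycyclohexyl group does. From the compounds shown here alone, it also remains open whether an amine or a carboxylic acid in place of that hydroxyl would be as indifferent to arrangement.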